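Methyl in Place of Chloro Beside the Amide

The source may hold more compounds than are shown below. What is called first, only, known or untested is meant among the compounds shown, and "the series" means these compounds.

Compound 1, `Cn1cc(-c2ccc(NC(=O)c3cn(CC4CCOCC4)cc(-c4ccc(F)cc4)c3=O)c(F)c2)c2c(N)ncnc21`: 0.2 nM
Compound 2, `Cn1cc(-c2ccc(NC(=O)c3cn(CC4CCOCC4)cc(-c4ccc(F)cc4)c3=O)c(Cl)c2)c2c(N)ncnc21`: 3.7 nM
Compound 3, `CC(C)n1cc(C(=O)Nc2cc(F)c(-c3c[nH]c4ncnc(N)c34)cc2F)c(=O)c(-c2ccc(F)cc2)c1`: < 0.2 nM

In an assay on isolated protein for inhibition of tyrosine-protein kinase receptor UFO (Homo sapiens), read by ELISA (a higher number here means a weaker inhibitor, a lower number a stronger inhibitor), compound 1 gives 0.2 nM. Compound 2 gives 3.7 nM, the highest number shown, and its nearest measured neighbour is compound 1. For compound 3 the value < 0.2 nM is a limit of the assay rather than a number (the limit of < 0.2 nM in this assay, at which 1 of the 3 values shown sits). Among the measured compounds shown here, the only measured step that reaches compound 2 is a 19-fold higher number from compound 1 to compound 2 (1.27 log units; beyond the scatter), a large one. Compound 4, `Cc1cc(-c2cn(C)c3ncnc(N)c23)ccc1NC(=O)c1cn(CC2CCOCC2)cc(-c2ccc(F)cc2)c1=O`, differs from compound 2 by methyl in place of chloro on an aromatic carbon. For the measured compounds named here, no measured step exchanges chloro for methyl, so the direction is uncertain, and a change within the scatter is expected: a 1.9-fold lower number from compound 2 to compound 4 (0.27 log units; within the scatter). Compound 4 is therefore estimated at 2 nM, between 0.4 nM and 10 nM.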

Compound 4, half-maximal inhibitory concentration: 4 nM
Beside the measured number, compound 4's estimate is 2.0-fold (0.30 log units) below it; low and high end bracket the measured number.
By their numbers in this assay, from the lowest: compound 1; then compounds 2 and 4 (each within the scatter of the next).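

Methyl and chloro on this aromatic carbon cannot be told apart, since the swap gives a 1.1-fold higher number from compound 2 to compound 4 (0.03 log units; within the scatter) and leaves the number where it was. Methyl in place of fluoro gives a 20-fold higher number from compound 1 to compound 4 (1.30 log units; beyond the scatter) and so, among these three groups, fluoro alone goes with the low number. The compounds shown offer no reason for this difference.

Still open, going by these compounds, is whether a plain hydrogen, a methoxy group or an amine on this carbon would match fluoro or fall with chloro and methyl.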